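Working notes: aryl change on a shared core

The compounds below may be only part of what the source reports. "The series", "measured", "known", "first", "only" and "open" are said of these compounds alone.

Compound 1 `OC[C@H]1O[C@@H](n2cnc3c(NCc4ccc(Cl)cc4Cl)ncnc32)[C@H](O)[C@@H]1O`: 127000 nM
Compound 2 `COc1cc(CNc2ncnc3c2ncn3[C@@H]2O[C@H](CO)[C@@H](O)[C@H]2O)cc(OC)c1`: > 166000 nM

In a functional assay on MCF cells (Homo sapiens) for antiproliferative activity, with a stated time of 72 h (a higher number here means a weaker inhibitor, a lower number a stronger inhibitor), compound 2 has no number: it sits at the limit of > 166000 nM in this assay, at which 1 of the 2 values shown sits. Compound 3 `OC[C@H]1O[C@@H](n2cnc3c(NCc4c(F)ccc(F)c4F)ncnc32)[C@H](O)[C@@H]1O` has not been measured and keeps the shared core of compound 2. The change is 2,3,6-trifluorophenyl in place of 3,5-dimethoxyphenyl on a saturated chain carbon bound to a nitrogen on an aromatic ring, with 2,3,6-trifluorophenyl in place of 3,5-dimethoxyphenyl on a saturated chain carbon bound to a nitrogen on an aromatic ring.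

Within the data shown here, one measured step bears on this place: an at least 1.3-fold higher number from compound 1 to compound 2 (0.11 log units; that floor lies within the scatter). It rests on a limit and gives no firm size for a change of this group. The nearest guide is compound 1 at 127000 nM, which, like compound 3, carries halogen atoms on its phenyl ring, though chlorine rather than fluorine. A value in the same region as compound 1 is therefore expected, and compound 3 may also end at a limit in this assay. The expected step is an at least 1.2-fold lower number from compound 2 to compound 3 (0.10 log units; that floor lies within the scatter), modest and toward a lower number, if it shows at all. For compound 3 the estimated value is 130000 nM, with an expected range of 60000 nM to 250000 nM.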

Compound 3, half-maximal inhibitory concentration: > 166000 nM
Compound 3: only a limit was reported; the forecaster's own chance of this, stated with the estimate: 35%; at least 1.2-fold (0.10 log units) between middle value and limit.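

In this assay, compound 3 sits at a limit and not at a number, as compound 2 does: the limit of > 166000 nM in this assay, at which 2 of the 3 values shown sit.

Among these compounds, the one readable step is an at least 1.3-fold higher number from compound 1 to compound 3 (0.11 log units; that floor lies within the scatter), so 2,3,6-trifluorophenyl and 2,4-dichlorophenyl are not firmly separated at this place, on a saturated chain carbon bound to a nitrogen on an aromatic ring. The step from compound 2 to compound 3 cannot be read, so 2,3,6-trifluorophenyl and 3,5-dimethoxyphenyl stay unordered, and the new finding is only that a fluorinated phenyl also gives no number in this assay.

Going by these compounds, the actual values of compound 2 and compound 3 remain open, and with them the size of any difference among the three aryl groups. Also open, on these data alone, is whether a phenyl ring bearing an amine or a carboxylic acid, or a longer chain in place of the single saturated carbon, would move a compound beyond the scatter from compound 1, which gives 127000 nM in this assay.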